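The compounds below may be only part of what the source reports. "The series", "measured", "known", "first", "only" and "open" are said of these compounds alone.

Working notes on the series. Compound 1 `Cc1nc(C)c(C(=O)Oc2ccccc2/C=C/C(=O)O)nc1C` gives 9600 nM in a functional assay on a cell-free system (Platelet, plasma, Oryctolagus cuniculus) for inhibition, with a stated time of 5 min, at 37 degrees C; a lower number here means a stronger inhibitor, a higher number a weaker inhibitor. Compound 2 `COc1ccc(OC(=O)c2nc(C)c(C)nc2C)c(/C=C/C(=O)O)c1` gives 49000 nM in this assay, and compound 3 `CCOC(=O)/C=C/c1cc(OC)c(OC(=O)c2nc(C)c(C)nc2C)c(OC)c1` gives 37500 nM in this assay. Compound 4 `CCOC(=O)/C=C/c1ccc(OC(=O)c2nc(C)c(C)nc2C)c(OC)c1` has not yet been measured.

Between compound 2 and compound 1 the change is hydrogen in place of methoxy on an aromatic carbon, which brought a 5.1-fold lower number from compound 2 to compound 1 (0.71 log units; beyond the scatter). From compound 3 to compound 4 the change is hydrogen in place of methoxy on an aromatic carbon, the same kind of change, though the surroundings differ: here the site is ortho to a large group and meta to a methoxy group, whereas in compound 2 it was para to a large group. The difference between the core of compound 2 and the core of compound 3 is not broken down here.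

In this assay, going by the values given here, the step is expected to be a 2.5-fold lower number from compound 3 to compound 4 (0.40 log units; beyond the scatter), kept smaller than the single precedent because a 5.1-fold lower number from compound 2 to compound 1 (0.71 log units; beyond the scatter) came from a differently placed site. Compound 4 is therefore estimated at 15000 nM, expected between 6000 nM and 40000 nM.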

Compound 4, half-maximal inhibitory concentration: 58400 nM
Estimate against measurement, compound 4: 3.9-fold (0.59 log units) below, outside the stated range (above it).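

In this assay the replacement of methoxy by hydrogen on the core of compound 3 gives a 1.6-fold higher number from compound 3 to compound 4 (0.19 log units; within the scatter) and so has no readable effect on this core. The change therefore does not carry over unaltered from one core to the other in this series: the same change on two cores in this assay, a 5.1-fold lower number (0.71 log units; beyond the scatter) from compound 2 to compound 1 and a 1.6-fold higher number (0.19 log units; within the scatter) from compound 3 to compound 4, 7.9-fold (0.90 log units) apart, beyond the scatter of two such steps

These two pairs do not show what sets the gap, since the cores differ both in the site of the methoxy group and in ethyl ester against free carboxylic acid. The compounds shown leave open how the change reads on an ester with a longer chain or on an amide in place of the ethyl ester. Also open, on these data alone, is whether a fluorine or a hydroxyl at the same site would follow hydrogen or methoxy.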